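Hydroxy in place of hydrogen on compound 1

This account rests on a few compounds, and the source may have more. Where it says the series, first, only, none or still open, it means among the compounds named here.

Compound 1, `O=C(/C=C(O)/C=C/c1ccc(O)cc1)c1cc(Cl)ccc1O`, gives 45.3% in an assay on isolated protein for inhibition of Alpha glucosidase (Homo sapiens), with stated times of 5 min and 15 min, tested at 50 uM; a lower number here means less inhibition, a higher number more inhibition at the concentration tested (going by the name of the read-out).
Compound 2, `O=C(/C=C(O)/C=C/c1ccc(O)cc1)c1ccccc1O`, gives 20.4% in this assay.
Compound 3, `O=C1/C(=C/c2ccccc2)CCC/C1=C\c1ccccc1F`, built on a different core, gives 43% in this assay.

Among the three measured compounds, compound 1 stands highest, with compound 3 nearest, its number lower by an amount within the scatter, and compound 2 furthest, lower by an amount beyond the scatter. Among the compounds with values here, the one step measured between compounds that differ in a single place, hydrogen in place of chloro on an aromatic carbon, is a number 24.9 percentage points lower from compound 1 to compound 2 (beyond the scatter), a modest loss.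

Compound 4, `O=C(/C=C(O)/C=C/c1ccc(O)c(O)c1)c1cc(Cl)ccc1O`, differs from compound 1 by hydroxy in place of hydrogen on an aromatic carbon. Within the data shown here, no measured step involves a hydroxy entering or leaving, so the step from compound 1 to compound 2 only shows that a single change on an aromatic ring of this core can move the number by a modest amount; it does not say in which direction the present change will go. The expectation for compound 4 is therefore a step of a number 4.7 percentage points higher from compound 1 to compound 4 (within the scatter), not confidently beyond the scatter.

Compound 4 is estimated to give 50% in this assay, within a range from 30% to 72%.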

Compound 4, a percentage reported as inhibition, at one concentration (the size of the read-out at that concentration, not a potency): 85.6%
Compound 4: the middle estimate sits 35.6 percentage points below what was measured, and the stated range ends below it.
By their numbers in this assay, from the lowest: compound 2; then compounds 3 and 1 (each within the scatter of the next); then compound 4.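

In this assay, within the data shown here, hydroxy in place of hydrogen on an aromatic carbon, ortho to a hydroxy group, gives a number 40.3 percentage points higher from compound 1 to compound 4 (beyond the scatter) and is the first measured gain from compound 1. Among these compounds, the only earlier step, a number 24.9 percentage points lower from compound 1 to compound 2 (beyond the scatter), showed a loss on removing chloro from the other aromatic ring, so it left this ring unexplored; the new step shows that this position is not indifferent to substitution and that a single added hydroxy here can raise the inhibition at the concentration tested. No measurement shown here bears on what lies behind this gain.

The compounds shown leave open whether the gain needs a hydroxy at this place or whether a methoxy, an amine or a fluorine there would raise the number as well. As far as these compounds go, they also leave open whether the same hydroxy would bring a comparable gain on compound 2, which carries hydrogen in place of chloro, so it remains unknown whether the two changes act independently of each other on the shared core.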